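A few compounds are considered here, and "the series" means these few. Any claim that something is new, unique, unknown or untested is made for them only; others in the source may bear on it.

Measured so far:
compound 1 `C[C@@H]1CN(c2sc(C(F)(F)F)nc2-c2nc3ccccc3[nH]2)CCN1C(=O)Cn1ccc(C(=O)O)n1`, 5570 nM
compound 2 `Cc1nn(CC(=O)N2CCN(c3sc(C(F)(F)F)nc3-c3nc4ccccc4[nH]3)C[C@H]2C)cc1CN(C)C`, 330 nM
compound 3 `Cc1nc(C)n(CC(=O)N2CCN(c3sc(C(F)(F)F)nc3-c3nc4ccc(OC5COC5)cc4[nH]3)C[C@H]2C)n1`, 1480 nM

In a functional assay on Venous blood for antagonist activity at C-X-C chemokine receptor type 3 (Homo sapiens), read by flow cytometry, with a stated time of 30 min, in the presence of a further agent that is not named here (on this read-out lower numbers stand for stronger inhibition and higher numbers for weaker inhibition), compound 1 gives the highest number of the three; compound 3 sits nearest, compound 2 furthest, both gaps beyond the scatter. Compound 4 `Cc1nc(C)n(CC(=O)N2CCN(c3sc(C(F)(F)F)nc3-c3nc4ccccc4[nH]3)C[C@H]2C)n1` has not been measured. It differs from compound 1 in one place: 3,5-dimethyl-1H-1,2,4-triazol-1-yl in place of 3-carboxy-1H-pyrazol-1-yl on a saturated chain carbon bound to a carbonyl carbon. Among the measured compounds shown here, the one recorded step at that place, a 17-fold lower number from compound 1 to compound 2 (1.23 log units; beyond the scatter), also takes away the carboxy group and is large. Compound 3 carries the same 3,5-dimethyl-1H-1,2,4-triazol-1-yl group, with a further substituent on the core, and gives 1480 nM, clearly under compound 1. A lower number is therefore expected for compound 4, by about a 4.6-fold lower number from compound 1 to compound 4 (0.67 log units; beyond the scatter). The estimate for compound 4 is 1200 nM, within 400 nM to 3500 nM.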

Compound 4, half-maximal inhibitory concentration: 237 nM
For compound 4 the middle estimate is 5.1-fold (0.70 log units) above the measured one; the whole stated range lies above it.
By their numbers in this assay, from the lowest: compounds 4 and 2 (each within the scatter of the next); then compound 3; then compound 1.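

Replacing 3-carboxy-1H-pyrazol-1-yl on the saturated chain carbon bound to a carbonyl carbon with 3,5-dimethyl-1H-1,2,4-triazol-1-yl gives a large step (a 24-fold lower number from compound 1 to compound 4 (1.37 log units; beyond the scatter)), and the gap to the 4-((dimethylamino)methyl)-3-methyl-1H-pyrazol-1-yl group stays within the scatter (a 1.4-fold lower number from compound 2 to compound 4 (0.14 log units; within the scatter)), so that basic-looking side group is not required for the large step. With this triazolyl group fixed, hydrogen in place of (oxetan-3-yl)oxy on an aromatic carbon gives a modest step (a 6.2-fold lower number from compound 3 to compound 4 (0.80 log units; beyond the scatter)). No available data explain either step.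

Open, as far as these compounds go, is whether a primary amide or a longer chain at this place would hold the number of compound 4. A methoxy group on the aromatic carbon also remains to be compared.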